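Trifluoromethyl to hydroxymethyl: clearance notes on the series

This account rests on a few compounds, and the source may have more. Where it says the series, first, only, none or still open, it means among the compounds named here.

Of the compounds shown here, three have been read in an ADME assay (liver) for metabolic stability, with Liver microsome (Rattus norvegicus) as the target, using microsomes and NADPH, with a stated time of 30 min, at 37 degrees C, tested at 1 uM (a higher number here means faster removal of the compound, a lower number slower removal), and none gives a number. Compound 1 `CC(O)(c1ccc(-c2ccc(S(=O)(=O)c3ccc(N)nc3)cc2)cc1)C(F)(F)F` reads < 14 mL.min-1.g-1, which is a limit. Compound 2 `COc1cc(C(O)(C(F)(F)F)C(F)(F)F)cnc1-c1ccc(S(=O)(=O)c2ccc(N)nc2)cc1` reads < 14 mL.min-1.g-1, also a limit. Compound 3 `C[C@@](O)(c1ccc(-c2ncc(S(=O)(=O)c3ccc(N)nc3)s2)c(Cl)c1)C(F)(F)F` reads < 14 mL.min-1.g-1, again a limit. Compound 3 therefore stands with the other two, and the whole set comes down to the limit of < 14 mL.min-1.g-1 in this assay, at which 3 of the 3 values shown sit. No ordering of the three can be drawn from these readings.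

The next compound is compound 4 `C[C@](O)(CO)c1ccc(-c2ncc(S(=O)(=O)c3ccc(N)nc3)s2)c(Cl)c1`, which keeps the core of compound 3 and changes one group. Hydroxymethyl takes the place of trifluoromethyl on a saturated chain carbon bound to an aromatic carbon, an oxygen on a saturated carbon and a saturated chain carbon, so that 1-hydroxy-1-(trifluoromethyl)ethyl becomes 1-hydroxy-1-(hydroxymethyl)ethyl: hydroxymethyl in place of trifluoromethyl on a saturated chain carbon bound to an aromatic carbon, an oxygen on a saturated carbon and a saturated chain carbon.

Among the measured compounds shown here, no measured pair shows what a single change does in this assay, so the expectation rests only on the shared limit of the three neighbours. No step beyond the scatter is expected, and the estimated step is a step that the limit leaves unreadable from compound 3 to compound 4. A reading at the same limit is the likeliest outcome. For compound 4 the expected value is 12 mL.min-1.g-1, with an estimated range of 7 mL.min-1.g-1 to 25 mL.min-1.g-1.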

Compound 4, intrinsic clearance in microsomes: < 14 mL.min-1.g-1
Compound 4: only a limit was reported (the forecaster's own chance of this, stated with the estimate: 75%); the middle value is on the limit's open side.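

No step can be read between compound 3 and compound 4 in this assay, since both readings are limits and the series sits at a single one: the limit of < 14 mL.min-1.g-1 in this assay, at which 4 of the 4 values shown sit.

The compounds shown leave open whether hydroxymethyl in place of trifluoromethyl alters clearance at all, and how the four compounds rank against one another.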